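From (2-fluorobenzyl)oxy to (3-chlorobenzyl)oxy on a shared core

The source may report more compounds than this note shows. Statements on the series, on what has been measured and on what is new or still open speak of the compounds shown alone.

Three compounds share one core and differ only in the group on a saturated chain carbon bound to an oxygen on an aromatic ring. Compound 1 `COc1cc(OC)c(-c2coc3cc(OCC=C(C)C)ccc3c2=O)cc1OC` carries 2-methylprop-1-en-1-yl there, compound 2 `COc1cc(OC)c(-c2coc3cc(OCc4ccccc4F)ccc3c2=O)cc1OC` carries 2-fluorophenyl, and compound 3 `COc1cc(OC)c(-c2coc3cc(OCc4ccc(F)cc4)ccc3c2=O)cc1OC` carries 4-fluorophenyl. In a functional assay on A-375 cells (Homo sapiens) for antiproliferative activity, read by MTT assay, with a stated time of 24 h (on this read-out lower numbers stand for stronger inhibition and higher numbers for weaker inhibition), compound 1 gives 1580 nM, compound 2 gives 2100 nM and compound 3 gives 1720 nM. Compound 2 sits at the top of the three numbers, yet the steps of a 1.3-fold higher number from compound 1 to compound 2 (0.12 log units; within the scatter) and a 1.2-fold lower number from compound 2 to compound 3 (0.09 log units; within the scatter) both fall within the scatter, so the three compounds cannot be told apart on these numbers.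

Compound 4 `COc1cc(OC)c(-c2coc3cc(OCc4cccc(Cl)c4)ccc3c2=O)cc1OC` has not yet been measured. Its difference from compound 2 is 3-chlorophenyl in place of 2-fluorophenyl on a saturated chain carbon bound to an oxygen on an aromatic ring. Going by the values given here, no measured step puts a chlorine onto this ring, but the step of a 1.2-fold lower number from compound 2 to compound 3 (0.09 log units; within the scatter) shows that a differently placed fluorine leaves the number essentially where it was, and a 1.1-fold higher number from compound 1 to compound 3 (0.04 log units; within the scatter) shows that exchanging the whole group for a fluorophenyl changes little as well. The expectation for compound 4 in this assay is therefore a step of a 1.1-fold lower number from compound 2 to compound 4 (0.04 log units; within the scatter), no larger than the scatter. Compound 4 is estimated at 1900 nM, within a range from 900 nM to 4000 nM.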

Compound 4, half-maximal inhibitory concentration: 980 nM
Compound 4: the middle estimate sits 1.9-fold (0.29 log units) above what was measured; measured number inside the range.
By their numbers in this assay, from the lowest: compounds 4, 1, 3 and 2 (each within the scatter of the next, the first and the last beyond it).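

In this assay, going by these compounds alone, the step of a 2.1-fold lower number from compound 2 to compound 4 (0.33 log units; beyond the scatter) is the first to pass the usual scatter, so the group on a saturated chain carbon bound to an oxygen on an aromatic ring can move the number after all, though only modestly. This separation holds only against compound 2: the steps of a 1.8-fold lower number from compound 3 to compound 4 (0.24 log units; within the scatter) and a 1.6-fold lower number from compound 1 to compound 4 (0.21 log units; within the scatter) stay inside the scatter, so compound 4 cannot be ranked above compound 3 or compound 1, and it cannot be called the strongest of the four. No accompanying measurement accounts for the step from 2-fluorobenzyl to 3-chlorobenzyl.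

That step changes the halogen and its printed place on the ring together, so the compounds shown cannot say whether the chlorine, its place, or both lie behind the difference from compound 2. Also open, as far as these compounds go, is how the number would respond to a plain phenyl with no halogen, a bromophenyl, a methoxyphenyl, or a longer chain ending in an amine at this same position.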